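Swapping the amide aryl group on a shared cytotoxic core

This account rests on a few compounds, and the source may have more. Where it says the series, first, only, none or still open, it means among the compounds named here.

Three compounds share one core and differ only in the group on a carbonyl carbon. Compound 1 `CC(Cl)CC(=O)NC1=C(C#N)C(c2ccc(Cl)cc2Cl)C2=C(CCCC2=O)N1c1ccc(S(N)(=O)=O)cc1` carries a 2-chloropropyl there, and in a functional assay on Ehrlich cells (Mus musculus) for cytotoxicity, read by trypan blue exclusion, with a stated time of 2 h, tested at 50 ug/mL (a higher number here means a stronger effect of the compound at the concentration tested, a lower number a weaker effect), compound 1 gives 55%. Compound 2 `N#CC1=C(NC(=O)/C=C/c2ccccc2)N(c2ccc(S(N)(=O)=O)cc2)C2=C(C(=O)CCC2)C1c1ccc(Cl)cc1Cl` carries a 2-phenylethenyl, and compound 2 gives 40%. Compound 3 `N#CC1=C(NC(=O)c2ccc([N+](=O)[O-])cc2)N(c2ccc(S(N)(=O)=O)cc2)C2=C(C(=O)CCC2)C1c1ccc(Cl)cc1Cl` carries a 4-nitrophenyl, and compound 3 gives 50%. For the measured compounds named here, the one step beyond the scatter is a number 15 percentage points lower from compound 1 to compound 2 (beyond the scatter); by contrast a number 5 percentage points lower from compound 1 to compound 3 (within the scatter) and a number 10 percentage points higher from compound 2 to compound 3 (within the scatter) both stay within it. The number for compound 3 thus sits between those of compound 1 and compound 2 and differs from each by no more than the scatter.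

Compound 4 `COc1cc(C(=O)NC2=C(C#N)C(c3ccc(Cl)cc3Cl)C3=C(CCCC3=O)N2c2ccc(S(N)(=O)=O)cc2)cc(OC)c1OC` changes this same position: 3,4,5-trimethoxyphenyl in place of 4-nitrophenyl on a carbonyl carbon. Every measured step exchanges a group on this carbonyl carbon, and all but one stayed within the scatter, with the largest only modest. Going by the values given here, no measured compound carries a 3,4,5-trimethoxyphenyl, so nothing points to a move in either direction. Compound 4 is therefore expected to give about 48%, between 30% and 65%. This expectation amounts to a number 2 percentage points lower from compound 3 to compound 4 (within the scatter).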

Compound 4, a percentage reported as activity, at one concentration (the size of the read-out at that concentration, not a potency): 95%
Beside the measured number, compound 4's estimate is 47 percentage points below it; the whole stated range lies below it.
By their numbers in this assay, from the lowest: compounds 2, 3 and 1 (each within the scatter of the next, the first and the last beyond it); then compound 4.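

In this assay the 3,4,5-trimethoxyphenyl gives a number 45 percentage points higher from compound 3 to compound 4 (beyond the scatter), along with a number 55 percentage points higher from compound 2 to compound 4 (beyond the scatter) and a number 40 percentage points higher from compound 1 to compound 4 (beyond the scatter), so this position can move the number far more than the first three groups showed. The 4-nitrophenyl and the 3,4,5-trimethoxyphenyl each hold one six-membered aromatic ring of carbon only, so having that ring on the carbonyl carbon does not by itself give the high number; compound 3 has it too. Nothing at hand explains why this exchange has so large an effect.

As far as these compounds go, it remains open whether all three methoxy groups are needed, and what a phenyl with one methoxy group, or with a hydroxyl or an amine, would give. A reading at one concentration shows the size of the effect of compound 4 at that concentration only, and leaves open how strong its effect would be at other concentrations.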